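The source may hold more compounds than are shown below. What is called first, only, known or untested is meant among the compounds shown, and "the series" means these compounds.

Working notes on the series.

Two compounds of the series have numbers in an ADME assay on cells (Hepatocyte, Rattus norvegicus) for metabolic stability; a lower number here means slower removal, a higher number faster removal of the compound. Compound 1 `Cc1ccc2[nH]c(C(=O)N[C@H]3CCN(S(=O)(=O)N(C)C)C[C@@H]3C(=O)NCCN(C)C)cc2c1` gives 10 uL/min in this assay. Compound 2 `Cc1ccc2[nH]c(C(=O)N[C@H]3CN(S(=O)(=O)c4ccccc4)C[C@@H]3C(=O)NC[C@@H]3CCCN3C)cc2c1` gives 23 uL/min in this assay, the higher of the two numbers, and the gap between compound 1 and compound 2 is beyond the usual scatter of repeated measurements. For the measured compounds named here, no step between these two is worked out here, as they differ in more than one place, so only their two values are read.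

Compound 3 `Cc1ccc2[nH]c(C(=O)N[C@H]3CN(S(=O)(=O)c4ccccc4)C[C@@H]3C(=O)N[C@@H]3CCCNC3)cc2c1` has not been measured in this assay. It differs from compound 2 in one place: piperidin-3-yl in place of (1-methylpyrrolidin-2-yl)methyl on an amide-type nitrogen. The change sits on the amide-type nitrogen whose other neighbour is the carbonyl carbon, and the remainder of compound 2 is kept.

Nothing measured in the series bears on this change, so the expectation rests on compound 2 alone. The step from compound 2 to compound 3 in this assay is expected to be small, a 1.4-fold lower number from compound 2 to compound 3 (0.16 log units; within the scatter), and not clearly beyond the scatter in either direction. Compound 3 is therefore estimated at 16 uL/min in this assay, with a range from 7 uL/min to 35 uL/min.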

Compound 3, intrinsic clearance in a liver preparation (reported as CLH), per the amount of preparation that the assay uses: 9 uL/min
Compound 3: middle estimate off by 1.8-fold (0.25 log units), on the high side; the range from low to high includes it.
By their numbers in this assay, from the lowest: compounds 3 and 1 (each within the scatter of the next); then compound 2.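

In this assay, for the compounds shown here, this is the first step that can be read at a single place: with the rest of compound 2 kept, piperidin-3-yl in place of (1-methylpyrrolidin-2-yl)methyl on the amide-type nitrogen gives a 2.6-fold lower number from compound 2 to compound 3 (0.41 log units; beyond the scatter). The number therefore responds to the group at this position, a point the two earlier compounds could not show, as they differ in more than one place. The step is modest, and it bundles several differences: a six-membered ring replaces a five-membered one, and the entering group carries a hydrogen-bond donor where the leaving group has none, while nothing at hand accounts for the step.

Which of these differences carries the step stays open, and 1-methylpiperidin-3-yl or pyrrolidin-2-ylmethyl on the same nitrogen would each change only part of the bundle. Also open, from the compounds shown here alone, is whether the same exchange gives a similar step when the phenylsulfonyl group of compound 2 is replaced by a dimethylaminosulfonyl group, as in compound 1.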